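This account rests on a few compounds, and the source may have more. Where it says the series, first, only, none or still open, it means among the compounds named here.

Compound 1 `COc1cc(-n2ncnc2-c2ccc(C)cc2)cc(OC)c1OC` carries a 4-methylphenyl group on the shared core. In a functional assay on HL-60 cells (Homo sapiens) for antiproliferative activity, read by MTT assay, with a stated time of 72 h (on this read-out lower numbers stand for stronger inhibition and higher numbers for weaker inhibition), compound 1 gives 90 nM, the lowest of the two numbers available; the nearest is compound 3 `COc1cc(-n2ncnc2-c2ccc(OC(C)C)cc2)cc(OC)c1OC`, which gives 700 nM in this assay. Compound 2 `COc1cc(-c2ncnn2-c2ccccc2)cc(OC)c1OC` gives only a limit of the assay, > 10000 nM, in this assay. Among the compounds with values here, the one measured step, a 7.8-fold higher number from compound 1 to compound 3 (0.89 log units; beyond the scatter), is modest but beyond the scatter. Compound 4 `COc1cc(-n2ncnc2-c2cccc(F)c2)cc(OC)c1OC` differs from compound 1 by 3-fluorophenyl in place of 4-methylphenyl on an aromatic carbon. Within the data shown here, no measured step exchanges a 4-methylphenyl for a 3-fluorophenyl, so the step from compound 1 to compound 3 is the only guide, and it shows that replacing the methyl on that phenyl ring weakened inhibition. A weakening of similar or somewhat smaller size is therefore expected for compound 4 in this assay, a step of a 5.6-fold higher number from compound 1 to compound 4 (0.74 log units; beyond the scatter). Compound 4 is estimated at 500 nM, with a range from 100 nM to 3000 nM.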

Compound 4, half-maximal inhibitory concentration: > 10000 nM
Compound 4: a limit, no number; the forecaster's own chance of this, stated with the estimate: 10%; at least 20-fold (1.30 log units) between middle value and limit.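

In this assay, exchanging 4-methylphenyl for 3-fluorophenyl on an aromatic carbon of the shared core gives an at least 110-fold higher number from compound 1 to compound 4 (2.04 log units; beyond the scatter), a large step, whereas the change on the phenyl ring seen earlier gave a 7.8-fold higher number from compound 1 to compound 3 (0.89 log units; beyond the scatter), a modest one. Within the data shown here, compound 4 gives a limit of the assay and not a number, and that limit is also the one reached by compound 2: the limit of > 10000 nM in this assay, at which 2 of the 4 values shown sit. The two exchanged groups are equal in heavy atoms and each holds one six-membered aromatic ring of carbon only, yet only compound 1 of this pair gives a number.

The compounds shown do not separate the change of substituent from its change of place, since neither 4-fluorophenyl nor 3-methylphenyl stands among them. On these data alone, whether an amine or a methoxy group on that phenyl ring would give a number also stays open.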